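The source may report more compounds than this note shows. Statements on the series, on what has been measured and on what is new or still open speak of the compounds shown alone.

Measured so far:

Compound 1, `CN1CCC(C(=O)N2Cc3c(NC(=O)c4ccco4)n[nH]c3C2(C)C)CC1`, gives only a limit in a functional assay on A2780 cells (Homo sapiens) for antiproliferative activity, read by fluorescence, with a stated time of 72 h; a lower number here means a stronger inhibitor, a higher number a weaker inhibitor: > 5000 nM.
Compound 2, `CN1CCC(C(=O)N2Cc3c(NC(=O)c4ccccc4)n[nH]c3C2(C)C)CC1`, gives 160 nM.
Compound 3, `CN1CCC(C(=O)N2Cc3c(NC(=O)c4ccc(C(F)(F)F)cc4)n[nH]c3C2(C)C)CC1`, gives 60 nM.

Compound 3 stands at the lowest number of the two that are actual numbers, with compound 2 the nearest to it. The value for compound 1 is a limit of the assay and not a number, which is stated by the limit of > 5000 nM in this assay, at which 1 of the 3 values shown sits.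

Compound 4, `CN1CCC(C(=O)N2Cc3c(NC(=O)c4ccc5ccccc5c4)n[nH]c3C2(C)C)CC1`, differs from compound 3 in one place: naphthalen-2-yl in place of 4-(trifluoromethyl)phenyl on a carbonyl carbon. Going by the values given here, two measured steps bear on this. The step of an at least 31-fold lower number from compound 1 to compound 2 (1.49 log units; beyond the scatter) and the step of an at least 83-fold lower number from compound 1 to compound 3 (1.92 log units; beyond the scatter) were both large, and both placed a six-membered aromatic ring of carbon only on the carbonyl carbon. The step of a 2.7-fold lower number from compound 2 to compound 3 (0.43 log units; beyond the scatter) was modest. Compound 4 keeps a six-membered aromatic ring of carbon only on that carbonyl carbon and adds a second such ring, so the change is expected to stay close to compound 3, with a step of a 1.3-fold higher number from compound 3 to compound 4 (0.12 log units; within the scatter) that may not exceed the scatter. Compound 4 is therefore estimated at 80 nM, within 25 nM to 250 nM.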

Compound 4, half-maximal inhibitory concentration: 270 nM
Beside the measured number, compound 4's estimate is 3.4-fold (0.53 log units) below it; the measured number lies above the stated range.
By their numbers in this assay, from the lowest: compound 3; then compounds 2 and 4 (each within the scatter of the next). At a limit, above all of these: compound 1.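

Adding a second six-membered aromatic ring of carbon only on the carbonyl carbon does not carry on the gain seen with trifluoromethyl: there is a 4.5-fold higher number from compound 3 to compound 4 (0.65 log units; beyond the scatter) and, against plain phenyl, only a 1.7-fold higher number from compound 2 to compound 4 (0.23 log units; within the scatter) within the usual scatter. The larger group is still far better placed than furan-2-yl, with an at least 18-fold lower number from compound 1 to compound 4 (1.26 log units; beyond the scatter) as the step, so all three compounds with a carbon-only aromatic ring here read lower than the furan-2-yl compound. Compound 1 gives a limit and not a number: the limit of > 5000 nM in this assay, at which 1 of the 4 values shown sits.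

Still open, on these data alone, is whether the gain in compound 3 is specific to trifluoromethyl, or would also appear with a chlorine, a methoxy group or an amine on that aromatic carbon. A pyridine ring on the carbonyl carbon would show whether the ring must contain carbon only.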